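Replacing oct-1-yn-1-yl with 4-cyanophenyl in compound 4

The compounds below may be only part of what the source reports. "The series", "measured", "known", "first", "only" and "open" are said of these compounds alone.

Compound 1 `Cn1cncc1C(OCc1ccc(C#N)cc1C#Cc1ccccn1)c1ccc(C#N)cc1` gives > 0.1 nM as a limit
Compound 2 `Cn1cncc1C(OCc1ccc(C#N)cc1C#Cc1ccc(-c2ccccc2)cc1)c1ccc(C#N)cc1` gives > 0.1 nM as a limit
Compound 3 `CCCCCCC#Cc1cc(C#N)ccc1COC(c1ccc(C#N)cc1)c1cncn1C` gives > 0.1 nM as a limit

In a functional assay on NIH3T3 cells (Mus musculus) (a higher number here means that more compound is needed for the effect, a lower number that less compound is needed), compound 3 stands at > 0.1 nM as a limit only. The whole series rests on the limit of > 0.1 nM in this assay, at which 3 of the 3 values shown sit, and so no number is known. Compound 4 `Cn1cncc1C(OCc1ccc(C#N)cc1-c1ccc(C#N)cc1)c1ccc(C#N)cc1` has 4-cyanophenyl in place of oct-1-yn-1-yl on an aromatic carbon, and 4-cyanophenyl in place of oct-1-yn-1-yl on an aromatic carbon gives the count. The nearest measured steps are a step that the two limits leave unreadable from compound 1 to compound 2 and a step that the two limits leave unreadable from compound 1 to compound 3 and a step that the two limits leave unreadable from compound 2 to compound 3 and none has a readable size. They therefore set neither a size nor a direction, and they give no reason to expect a step beyond the scatter. The expected outcome is a step that the limit leaves unreadable from compound 3 to compound 4 with no firm direction. Compound 4 is estimated at 0.4 nM within a range of 0.08 nM to 5 nM.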

Compound 4, half-maximal effective concentration: < 0.1 nM
Compound 4: a limit, no number (the forecaster's own chance of this, stated with the estimate: 60%); middle value at least 4.0-fold (0.60 log units) away from the limit.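

In this assay, putting 4-cyanophenyl on this aromatic carbon gives a number no higher from compound 3 to compound 4 (the limit leaves the size open), and the same group in place of 2-(pyridin-2-yl)ethynyl gives a number no higher from compound 1 to compound 4 (the limit leaves the size open). For the compounds shown here, this is the first readable direction at this position, as the changes among the three alkynes left every step unreadable. Compound 4 alone sits at the lower limit: the limit of < 0.1 nM in this assay, at which 1 of the 4 values shown sits.

As far as these compounds go, the sizes of both steps cannot be read, so how far compound 4 lies past its limit stays open. Also open, from the compounds shown here alone, is how a plain phenyl or a 4-aminophenyl would read here, which would separate the share of the nitrile from that of the ring.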